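This account rests on a few compounds, and the source may have more. Where it says the series, first, only, none or still open, it means among the compounds named here.

Measured in a functional assay for inhibition, with Sus scrofa as the target; a lower number here means a stronger inhibitor, a higher number a weaker inhibitor:
- compound 1 `Cn1nc(O[C@@H]2c3cc(C#N)ccc3OC(C)(C)[C@H]2O)ccc1=O`: 50 nM
- compound 2 `CC1(C)Oc2ccc(C#N)cc2[C@@H](n2ccccc2=O)[C@]1(C)O`: > 100000 nM (a limit, not a number)

Compound 1 gives a true number, 50 nM. Compound 2 gives only a limit, > 100000 nM. Within the data shown here, no step that differs in one place links these two compounds.

Compound 3 `CC1(C)Oc2ccc(C#N)cc2[C@@H](N2CCCC2=O)[C@]1(C)O` follows from compound 2 by one change on the shared core: a group of 6 heavy atoms (4 carbon, 1 nitrogen, 1 oxygen; one five-membered non-aromatic ring with 1 hetero atom) in place of a group of 7 heavy atoms (5 carbon, 1 nitrogen, 1 oxygen; one six-membered aromatic ring with 1 hetero atom), on a saturated ring carbon. The 2-oxopyrrolidin-1-yl group sits on a saturated ring carbon, next to the ring atom that bears a hydroxy group.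

The expectation rests on compound 2, whose > 100000 nM is a limit. The expected change, an at least 2.0-fold lower number from compound 2 to compound 3 (0.30 log units; that floor lies within the scatter), is small and towards a stronger inhibitor, and a second limit is quite possible. Compound 3 is estimated at 50000 nM, with an expected range of 5000 nM to 100000 nM.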

Compound 3, half-maximal inhibitory concentration: 4000 nM
For compound 3 the middle estimate is 13-fold (1.10 log units) above the measured one, outside the stated range (below it).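

On the saturated ring carbon next to the ring atom that bears a hydroxy group, putting 2-oxopyrrolidin-1-yl in place of the six-membered aromatic ring group gives, in this assay, an at least 25-fold lower number from compound 2 to compound 3 (1.39 log units; beyond the scatter). The group at this place therefore has a clear bearing on the read-out, and with this five-membered non-aromatic ring compound 3 gives a true number, 4000 nM. The size of the step is only a floor, since compound 2 stands at a limit and not at a number: the limit of > 100000 nM in this assay, at which 1 of the 3 values shown sits.

The single change alters ring size and aromatic character together, so the compounds shown do not tell which of the two carries the step. Among these compounds, also open is how an open-chain amide, a piperidin-2-one ring or a simple amine would read on this carbon, and no single-place step ties compound 1 to the other two.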